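The source may hold more compounds than are shown below. What is called first, only, known or untested is meant among the compounds shown, and "the series" means these compounds.

Measured compounds: compound 1 `CC(C)C(=O)NC(C(=O)N1CCC(c2ccc(Cl)cc2)CC1)C(C)C` gives 388 nM in an assay on THP-1 cells for displacement of a labelled ligand from C-C chemokine receptor type 1 (Homo sapiens); a lower number here means a stronger inhibitor, a higher number a weaker inhibitor; compound 2 `Cc1ccc(C(=O)N[C@@H](C(=O)N2CCC(c3ccc(Cl)cc3)CC2)C(C)C)cc1` gives 25 nM; compound 3 `CC(C)C(NS(=O)(=O)Cc1ccccc1)C(=O)N1CCC(c2ccc(Cl)cc2)CC1` gives 303 nM.

Compound 2 stands lowest of the three and is the strongest inhibitor here, the other two lying well beyond the scatter from it. Compound 4 `Cc1ccccc1CCC(=O)N[C@@H](C(=O)N1CCC(c2ccc(Cl)cc2)CC1)C(C)C` differs from compound 2 by 2-(2-methylphenyl)ethyl in place of 4-methylphenyl on a carbonyl carbon. Within the data shown here, no measured step covers this kind of change: the only step, a 1.3-fold lower number from compound 1 to compound 3 (0.11 log units; within the scatter), concerns the group on the amine nitrogen and is within the scatter. Compound 1 and compound 2 show that an aromatic group bound directly to the carbonyl carbon gives a far lower number than an aliphatic one. Since compound 4 sets the ring apart from the carbonyl by a two-carbon chain, a step of a 6.0-fold higher number from compound 2 to compound 4 (0.78 log units; beyond the scatter) is expected, and compound 4 is estimated at 150 nM (range 40 nM to 600 nM).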

Compound 4, half-maximal inhibitory concentration: 19 nM
Compound 4: the middle estimate sits 7.9-fold (0.90 log units) above what was measured; measured number outside the range, below it.
By their numbers in this assay, from the lowest: compounds 4 and 2 (each within the scatter of the next); then compounds 3 and 1 (each within the scatter of the next).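

Across this assay, the carbonyl carbon accepts 2-(2-methylphenyl)ethyl in place of 4-methylphenyl with a 1.3-fold lower number from compound 2 to compound 4 (0.12 log units; within the scatter). Among these compounds, the aromatic ring therefore need not be bound directly to the carbonyl carbon for the number to stay at the level of compound 2, which the earlier compounds could not show. No measurement shown here accounts for this result.

The compounds shown do not separate the added chain from the altered methylphenyl group. Going by these compounds, whether a longer chain, or an amine or carboxylic acid on that chain, would be accepted also remains open.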